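The compounds below may be only part of what the source reports. "The series", "measured", "known", "first", "only" and "open" are said of these compounds alone.

In an ADME assay on microsomes from liver (Mus musculus) for metabolic stability (a lower number here means slower removal, a higher number faster removal of the compound), compound 1 `CN1C(=O)C2=C(C1=O)N(CC(=O)Nc1ccc(-c3ccccc3)cc1)CCC2` gives 25 mL.min-1.g-1. Going by the values given here, the only other measured compound, compound 2 `CN1C(=O)C2=C(C1=O)N(CC(=O)Nc1ccc(-c3ccccc3)nn1)CCC2`, gives 36 mL.min-1.g-1. These two values lie within the scatter of each other, so compound 1 does not stand apart from compound 2 on these numbers. Compound 3 `CN1C(=O)C2=C(C1=O)N(CC(=O)Nc1ccc(-c3ccccn3)cc1)CCC2` keeps the core of compound 1 and carries a single exchange: pyridin-2-yl in place of phenyl on an aromatic carbon, on a six-membered aromatic ring of carbon only, para to a large group (pyridin-2-yl in place of phenyl on an aromatic carbon). Among the compounds with values here, no measured pair isolates this exchange, so the data offer no direct step to lean on. Within the data shown here, the one guide is how close compound 2 at 36 mL.min-1.g-1 stays to compound 1 at 25 mL.min-1.g-1. A shift beyond the scatter is therefore not expected in this assay, and no firm direction can be assigned. The estimated change a 1.1-fold lower number from compound 1 to compound 3 (0.04 log units; within the scatter) is expected to be small. For compound 3 the estimated value is 23 mL.min-1.g-1, with an expected range of 12 mL.min-1.g-1 to 44 mL.min-1.g-1.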

Compound 3, intrinsic clearance in microsomes: 38 mL.min-1.g-1
Compound 3: middle estimate off by 1.7-fold (0.22 log units), on the low side; measured number inside the range.
By their numbers in this assay, from the lowest: compounds 1, 2 and 3 (each within the scatter of the next).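

Going by these compounds alone, the exchange of phenyl for pyridin-2-yl gives the first direct reading at this position, on an aromatic carbon of a six-membered aromatic ring of carbon only, para to a large group. In this assay the step is a 1.5-fold higher number from compound 1 to compound 3 (0.18 log units; within the scatter), so this single exchange cannot be told apart from repeat measurement of compound 1, even though it brings a ring nitrogen and one hydrogen-bond acceptor into a group of the same heavy-atom count. No measurement shown here accounts for the size of this step or connects it to any property of the two groups.

The compounds shown leave open whether pyridin-3-yl or pyridin-4-yl in this same place would also stay within the scatter of compound 1, so this one exchange cannot yet be read as a rule for ring nitrogens at this position. They also leave open whether a different kind of group here, such as morpholine, an amine or a carboxylic acid, would produce a step in this assay that lies beyond the scatter.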